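Capping the Hydroxypropyl Arm of Compound 2

The compounds below may be only part of what the source reports. "The series", "measured", "known", "first", "only" and "open" are said of these compounds alone.

Of the compounds shown here, two from this series have been measured in an in vitro assay on Sf9 cells for inhibition of cytochrome P450 2J2 (Homo sapiens); on this read-out lower numbers stand for stronger inhibition and higher numbers for weaker inhibition. Compound 1 `O=C(CCCN1CCC(C(O)(c2ccccc2)c2ccccc2)CC1)c1ccc(Br)cc1` gives 4200 nM, and compound 2 `O=C(CCCN1CCC(C(O)(c2ccccc2)c2ccccc2)CC1)c1ccc(CCCO)cc1` gives 1900 nM. Within the data shown here, compound 2 thus stands lowest of the two numbers, and the only step between them, a 2.2-fold lower number from compound 1 to compound 2 (0.34 log units; beyond the scatter), is the single measured change in this set.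

Compound 3 `CC(=O)OCCCc1ccc(C(=O)CCCN2CCC(C(O)(c3ccccc3)c3ccccc3)CC2)cc1` has not yet been measured. It differs from compound 2 by acetyl in place of hydrogen on an oxygen on a saturated carbon. Among the measured compounds shown here, no measured step covers this kind of change: the one step on record, a 2.2-fold lower number from compound 1 to compound 2 (0.34 log units; beyond the scatter), concerns 3-hydroxypropyl in place of bromo on an aromatic carbon, not the hydroxy at the end of that chain, so it bears only loosely on what happens when that hydroxy becomes an acetoxy. Since even the larger swap between compound 1 and compound 2 produced only a modest shift, a change of comparable or smaller size is expected here, in either direction, and most likely no step beyond the scatter. The estimate for compound 3 is therefore 1900 nM, with a range from 800 nM to 4500 nM, corresponding to no change at the digits printed from compound 2 to compound 3 (within the scatter).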

Compound 3, half-maximal inhibitory concentration: 2500 nM
Beside the measured number, compound 3's estimate is 1.3-fold (0.12 log units) below it, within the range that was stated.
By their numbers in this assay, from the lowest: compounds 2, 3 and 1 (each within the scatter of the next, the first and the last beyond it).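

In this assay, acetyl in place of hydrogen on the terminal oxygen of the arm gives a 1.3-fold higher number from compound 2 to compound 3 (0.12 log units; within the scatter), so this site tolerates the added 3 heavy atoms and an entering group with 0 hydrogen-bond donors without a step that can be told from the scatter. Measured against bromo, the 3-acetoxypropyl group gives a 1.7-fold lower number from compound 1 to compound 3 (0.23 log units; within the scatter), whereas 3-hydroxypropyl gave a 2.2-fold lower number from compound 1 to compound 2 (0.34 log units; beyond the scatter), which leaves compound 3 within the scatter of both compound 1 and compound 2, although those two lie beyond the scatter of each other. Nothing in hand explains this result, and no evidence bears on it.

The compounds shown leave open whether any group at the end of the propyl chain can move the number beyond the scatter from compound 2, as an amine, a carboxylic acid or a longer chain ending in hydroxy might. They also leave open how much the arm itself contributes, since bromo, 3-hydroxypropyl and 3-acetoxypropyl are the only groups shown on that aromatic carbon.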